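The source may report more compounds than this note shows. Statements on the series, on what has been measured and on what is new or still open speak of the compounds shown alone.

Measured so far:
- compound 1, `CCOC(=O)C1=Cc2ccccc2OC1(OCc1cn(-c2ccc(C)cc2)nn1)C(F)(F)F`: 30200 nM
- compound 2, `O=C(O)C1=Cc2ccccc2OC1(OCc1cc(-c2ccc([N+](=O)[O-])cc2)no1)C(F)(F)F`: 100000 nM

Both were run in a functional assay on DU-145 cells (Homo sapiens) for inhibition, read by MTT assay, with a stated time of 24 h; a lower number here means a stronger inhibitor, a higher number a weaker inhibitor. Compound 1 gives 30200 nM, the lower of the two numbers; compound 2 gives 100000 nM, beyond the scatter from compound 1. For the measured compounds named here, no pair that differs in one place has been measured, so no step size is established.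

Compound 3, `CCOC(=O)C1=Cc2ccccc2OC1(OCc1cn(-c2cccc(C(F)(F)F)c2)nn1)C(F)(F)F`, is not yet measured. It differs from compound 1 by 3-(trifluoromethyl)phenyl in place of 4-methylphenyl on an aromatic nitrogen. Going by the values given here, with no measured step of this kind, the expected step from compound 1 to compound 3 is a 1.0-fold lower number from compound 1 to compound 3 (0.00 log units; within the scatter), not beyond the scatter in either direction. Compound 3 is therefore estimated at 30000 nM, within 10000 nM to 100000 nM.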

Compound 3, half-maximal inhibitory concentration: > 150000 nM
Compound 3: only a limit was reported (the forecaster's own chance of this, stated with the estimate: 30%); middle value at least 5.0-fold (0.69 log units) away from the limit.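

In this assay the group on the aromatic nitrogen of the five-membered ring matters: 3-(trifluoromethyl)phenyl in place of 4-methylphenyl gives an at least 4.9-fold higher number from compound 1 to compound 3 (0.69 log units; beyond the scatter) as the first step readable in the series. Compound 3 is reported only as the limit > 150000 nM and the step rests on it: the limit of > 150000 nM in this assay, at which 1 of the 3 values shown sits.

Still open, as far as these compounds go, is whether the change of group or its ring position carries this step, which 4-(trifluoromethyl)phenyl or 3-methylphenyl on the same nitrogen would separate. From the compounds shown here alone, how an amine or a carboxylic acid on this phenyl ring would read also remains open.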